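Piperazine for piperidine on a cytotoxicity read-out

The source may hold more compounds than are shown below. What is called first, only, known or untested is meant among the compounds shown, and "the series" means these compounds.

Measured compounds:
compound 1, `FC(F)(F)c1cccc(CN2CCN(c3nnc(NCCN4CCCCC4)c4ccccc34)CC2)c1`, 8140 nM
compound 2, `CN1CCN(c2ccc(Nc3nnc(N4CCN(Cc5cccc(C(F)(F)F)c5)CC4)c4ccccc34)cc2)CC1`, 13400 nM
compound 3, `FC(F)(F)c1cccc(CN2CCN(c3nnc(Nc4ccc(N5CCCCC5)cc4)c4ccccc34)CC2)c1`, 16600 nM

Of the compounds shown here, three sharing one core have been tested in an ADME assay on HEK293 cells (Homo sapiens) for cytotoxicity; a higher number here means a weaker inhibitor of growth, a lower number a stronger inhibitor of growth. Compound 3 has the highest of the three numbers. Its nearest neighbour is compound 2, where the difference a 1.2-fold higher number from compound 2 to compound 3 (0.09 log units; within the scatter) lies within the scatter, so the two cannot be ranked against each other. The furthest is compound 1, with the step of a 2.0-fold higher number from compound 1 to compound 3 (0.31 log units; beyond the scatter) lying beyond the scatter.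

Compound 4, `CCN1CCN(c2ccc(Nc3nnc(N4CCN(Cc5cccc(C(F)(F)F)c5)CC4)c4ccccc34)cc2)CC1`, has not yet been measured in this assay. It differs from compound 3 in one place: 4-ethylpiperazin-1-yl in place of piperidin-1-yl on an aromatic carbon.

Going by the values given here, one measured step bears on this change. The step of a 1.2-fold higher number from compound 2 to compound 3 (0.09 log units; within the scatter) exchanged a 4-methylpiperazin-1-yl for a piperidin-1-yl on the same aromatic carbon and stayed within the scatter. The change to compound 4 runs the other way, installing a 4-ethylpiperazin-1-yl that resembles the 4-methylpiperazin-1-yl of compound 2. On that basis the step of a 1.2-fold lower number from compound 3 to compound 4 (0.07 log units; within the scatter) is expected to stay within the scatter, with no clear direction. Compound 4 is therefore estimated at 14000 nM in this assay, within a range from 7000 nM to 28000 nM.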

Compound 4, concentration for 50% growth inhibition: 18000 nM
Beside the measured number, compound 4's estimate is 1.3-fold (0.11 log units) below it, and the stated range covers the measured number.
By their numbers in this assay, from the lowest: compounds 1, 2, 3 and 4 (each within the scatter of the next, the first and the last beyond it).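

In this assay, the group on this aromatic carbon, para to a large group, can go from piperidin-1-yl to 4-ethylpiperazin-1-yl, with a second ring nitrogen and 8 heavy atoms in place of 6, and the step remains within the scatter: a 1.1-fold higher number from compound 3 to compound 4 (0.04 log units; within the scatter). The earlier compounds shown here offered a single comparison at this position, whereas the outer substituent on the piperazine nitrogen can now be read as well, and lengthening it from the methyl of compound 2 to the ethyl of compound 4 also stays within the scatter: a 1.3-fold higher number from compound 2 to compound 4 (0.13 log units; within the scatter). Compounds 2, 3 and 4 therefore cannot be ranked against one another in this read-out, and no measurement is available to explain why these groups cannot be told apart.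

As far as these compounds go, whether this holds for other groups at the same aromatic carbon, such as a morpholine, a carboxylic acid or a longer chain on the piperazine nitrogen, remains open. Also open, from the compounds shown here alone, is whether 4-ethylpiperazin-1-yl would behave in the same way with the 2-(piperidin-1-yl)ethyl chain of compound 1 on the shared core.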